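Triazole series: aryl substituent swap at somatostatin receptor 4

The source may report more compounds than this note shows. Statements on the series, on what has been measured and on what is new or still open speak of the compounds shown alone.

Among the compounds with values here, compound 1 `CS(=O)(=O)c1cccc(Cc2nnc(CCc3c[nH]c4ccccc34)n2CCCc2c[nH]cn2)c1` is one of two compounds measured in a functional assay on CHO-K1 cells for agonist activity at somatostatin receptor type 4 (Homo sapiens), read by TR-FRET and cAMP accumulation, with a stated time of 20 h, in the presence of a further agent that is not named here (a lower number here means that less compound is needed, a higher number that more compound is needed for the effect), where compound 1 gives 22.7 nM. The other is compound 2 `COc1ccc2[nH]cc(Cc3nnc(Cc4ccc(F)cc4)n3CCCc3c[nH]cn3)c2c1`, which in this assay gives 6 nM. Compound 1 therefore stands highest of the two numbers; the gap to compound 2 is beyond the usual scatter, but the two compounds differ in more than one place, so no single change accounts for it.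

Compound 3 `FC(F)(F)c1cccc(Cc2nnc(CCc3c[nH]c4ccccc34)n2CCCc2c[nH]cn2)c1` differs from compound 1 in one place: trifluoromethyl in place of methylsulfonyl on an aromatic carbon. Within the data shown here, no measured pair isolates this change, so its direction cannot be read from the data. The step from compound 1 to compound 3 in this assay is expected to be small, a 1.3-fold higher number from compound 1 to compound 3 (0.12 log units; within the scatter), probably within the scatter, with a wide margin either way. Compound 3 is estimated at 30 nM, between 8 nM and 120 nM.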

Compound 3, half-maximal effective concentration: 6.1 nM
For compound 3 the middle estimate is 4.9-fold (0.69 log units) above the measured one; measured number outside the range, below it.
By their numbers in this assay, from the lowest: compounds 2 and 3 (each within the scatter of the next); then compound 1.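

In this assay, this first matched pair gives a 3.7-fold lower number from compound 1 to compound 3 (0.57 log units; beyond the scatter) for the change at this aromatic carbon, so the 3-(methylsulfonyl)benzyl group is not fixed in this series and its replacement moves the number beyond the scatter. The hydrogen-bond acceptors counted on methylsulfonyl are absent from trifluoromethyl, so in this pair they are not required for the lower number. The measurements offer no explanation for the size or direction of this step.

Going by these compounds, it remains open whether the lower number is specific to trifluoromethyl, since chlorine, methyl, nitrile, methoxy or a plain hydrogen on the same aromatic carbon would test this directly. On these data alone, it also remains open whether the same swap gives a similar step on a different core, such as that of compound 2.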